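The source may hold more compounds than are shown below. What is called first, only, known or untested is meant among the compounds shown, and "the series" means these compounds.

Compound 1 `COc1ccc(F)cc1CNCCCNc1ccnc2cc(Cc3ccc(C#N)cc3)ccc12` is one of three compounds whose acid dissociation has been measured in a physicochemical assay for acid dissociation. In this assay compound 1 gives 9.47, which at the digits shown is level with compound 2 `FC(F)(F)c1ccc(-c2ccc3c(NCCCNCc4ccco4)ccnc3c2)cc1`, whose value in this assay is 9.47; these two together sit at the top of the three numbers, though their gap to compound 3 is within the scatter. Within the data shown here, compound 3 `CN(C)c1cccc(Oc2ccc3c(NCCCNCc4ccco4)ccnc3c2)c1` gives 9.28 in this assay, and the only single-site step among the measured compounds, a number 0.19 log units lower from compound 2 to compound 3 (within the scatter), swapped one group on an aromatic carbon of the shared core without moving the number beyond the scatter.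

Compound 4 `COc1ccc(F)cc1CNCCCNc1ccnc2cc(CCC(C)C)ccc12` has not yet been measured. It differs from compound 1 in one place: isobutyl in place of 4-cyanophenyl on a saturated chain carbon bound to an aromatic carbon. The 4-cyanophenyl group leaves and an isobutyl group enters, on a saturated chain carbon bound to an aromatic carbon of the core. Among the measured compounds shown here, the one measured step, from compound 2 to compound 3, also exchanged a group attached to the core and stayed within the scatter, so the step from compound 1 to compound 4 in this assay is expected to be similarly small, a number 0.03 log units higher from compound 1 to compound 4 (within the scatter), with no direction beyond the scatter. Compound 4 is therefore estimated at 9.5 in this assay, in the range from 9.2 to 9.8.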

Compound 4, acid dissociation constant: 9.47
Compound 4: the middle estimate sits 0.03 log units above what was measured, and the stated range covers the measured number.
By their numbers in this assay, from the lowest: compounds 3, 1, 2 and 4 (each within the scatter of the next).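

In this assay, replacing 4-cyanophenyl with isobutyl on a saturated chain carbon bound to an aromatic carbon gives no change at the digits printed from compound 1 to compound 4 (within the scatter), the first step shown at this place on the core of compound 1. The change is a large one in structural terms: a six-membered aromatic ring and a nitrile leave, the group shrinks from 8 heavy atoms to 4, and its single hydrogen-bond acceptor is lost, yet the number stays level, so for this pair the read-out does not register the exchange of an aromatic group with a nitrile for a plain saturated chain. No available data say why the number holds steady across this change.

What the compounds shown leave open is whether a group of another kind at this place, such as an amine or a carboxylic acid, would move the number beyond the scatter. On these data alone, it is also open whether a longer chain or a much smaller group such as methyl would leave it just as steady.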